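Bromo to Fluoro Exchange on the Fused Ring

The source may hold more compounds than are shown below. What is called first, only, known or untested is meant among the compounds shown, and "the series" means these compounds.

Measured so far:
Compound 1 `COC(=O)[C@@]1(C)C[C@@H](c2coc3ccc(Br)cc3c2=O)N(c2ccccc2)O1`: > 60000 nM in a functional assay on PC-3 cells (Homo sapiens) for inhibition, read by sulforhodamine B assay, with a stated time of 48 h (on this read-out higher numbers stand for weaker inhibition and lower numbers for stronger inhibition), a limit of the assay and not a number.
Compound 2 `O=c1c([C@@H]2C[C@H](c3ccccc3)ON2c2ccccc2)coc2ccc(F)cc12`: in this assay compound 2 gives 49000 nM.
Compound 3 `O=c1c([C@@H]2C[C@H](c3ccccc3)ON2c2ccccc2)coc2ccc(Br)cc12`: in this assay compound 3 gives 60000 nM.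

Compound 1 sits at the limit of > 60000 nM in this assay, at which 1 of the 3 values shown sits. The change from compound 3 to compound 2 is fluoro in place of bromo on an aromatic carbon and makes a step of a 1.2-fold lower number from compound 3 to compound 2 (0.09 log units; within the scatter). Compound 4 `COC(=O)[C@@]1(C)C[C@@H](c2coc3ccc(F)cc3c2=O)N(c2ccccc2)O1` has not yet been measured; it carries the same change relative to compound 1, (fluoro in place of bromo on an aromatic carbon), at a place described in the same words. The difference between the core of compound 1 and the core of compound 3 is not broken down here, so the two pairs are compared only through the shared exchange.

For compound 4 the expected step in this assay is a number no higher from compound 1 to compound 4 (the limit leaves the size open). This expectation rests on the step of a 1.2-fold lower number from compound 3 to compound 2 (0.09 log units; within the scatter), which lies within the scatter. It also rests on compound 1 sitting at the limit of > 60000 nM in this assay, at which 1 of the 3 values shown sits, so a limit rather than a number is the more likely outcome. Compound 4 is estimated at 60000 nM, within 35000 nM to 120000 nM in this assay.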

Compound 4, half-maximal inhibitory concentration: 31300 nM
Compound 4: middle estimate off by 1.9-fold (0.28 log units), on the high side; measured number below the stated range.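

Carried to the second core, fluoro in place of bromo on an aromatic carbon gives an at least 1.9-fold lower number from compound 1 to compound 4 (0.28 log units; that floor lies within the scatter) in this assay. This does not show that the exchange acts differently on the two cores, nor does it show that it acts alike: the same change on two cores in this assay, a 1.2-fold lower number (0.09 log units; within the scatter) from compound 3 to compound 2 and an at least 1.9-fold lower number (0.28 log units; that floor lies within the scatter) from compound 1 to compound 4; the limit leaves it open whether they differ. Compound 1 stands at a limit and not a number, so the full size of its step stays unknown: the limit of > 60000 nM in this assay, at which 1 of the 4 values shown sits.

On these data alone, what a chloro group, a methoxy group or an amine would give at this place on the ring stays open, as does whether the step would hold with a carboxylic acid in place of the methyl ester. Equally open, as far as these compounds go, is how the exchange would read on cells other than those of this assay.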